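The source may hold more compounds than are shown below. What is called first, only, known or untested is meant among the compounds shown, and "the series" means these compounds.

Compound 1 `COc1cc(/C=C2\CN(C)C/C(=C\c3cccnc3)C2=O)cc(OC)c1`: 7900 nM
Compound 2 `CN1C/C(=C\c2ccncc2)C(=O)/C(=C/c2ccccc2F)C1`: 4900 nM
Compound 3 `O=C1/C(=C/c2cccnc2)CN(S(=O)(=O)c2ccccc2)C/C1=C\c1ccccc1F`: 4800 nM

In a functional assay on QGY-7703 cells (Homo sapiens) for cytotoxicity, read by MTT assay, with a stated time of 24 h (a higher number here means a weaker inhibitor, a lower number a stronger inhibitor), compound 3 stands at 4800 nM and lies within the usual scatter of both compound 1 and compound 2, so the three cannot be separated. Compound 4 `O=C1/C(=C/c2cccnc2)CN(S(=O)(=O)c2ccc(Br)cc2)C/C1=C\c1ccccc1F` changes compound 3 by one substitution, phenylsulfonyl to (4-bromophenyl)sulfonyl, with bromo in place of hydrogen on an aromatic carbon, para to a large group: bromo in place of hydrogen on an aromatic carbon. Among the measured compounds shown here, no measured pair differs in only one place, so no direct precedent exists. Compound 1 at 7900 nM and compound 3 at 4800 nM remain within the scatter despite differing in several places, so no step beyond the scatter is expected in this assay here. The expected change is a 1.2-fold lower number from compound 3 to compound 4 (0.08 log units; within the scatter) and no larger. For compound 4 the estimated value is 4000 nM with an expected range from 1700 nM to 9500 nM in this assay.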

Compound 4, half-maximal inhibitory concentration: 12800 nM
Compound 4: the middle estimate sits 3.2-fold (0.51 log units) below what was measured, outside the stated range (above it).
By their numbers in this assay, from the lowest: compounds 3, 2, 1 and 4 (each within the scatter of the next, the first and the last beyond it).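

In this assay, among the compounds shown here, bromo in place of hydrogen on an aromatic carbon, para to a large group, gives a 2.7-fold higher number from compound 3 to compound 4 (0.43 log units; beyond the scatter) and so moves the number in the weaker direction, which the earlier compounds, all within the scatter of one another, could not show. This position on the phenylsulfonyl group therefore does not tolerate every substituent without a change in this assay. Nothing available here accounts for the step. The compounds shown leave open whether this step is specific to bromo. They also leave open how an amine, a methoxy group or a carboxylic acid at that place would read.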